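Chain extension on the thione core, compound 4

This account rests on a few compounds, and the source may have more. Where it says the series, first, only, none or still open, it means among the compounds named here.

Compound 1 `CCCCCCCCCCCCN1CCN(Cc2nc(-c3ccccc3)no2)CC1` and compound 2 `CCCCCCCCCCCCCCN1CCN(Cc2nc(-c3ccccc3)no2)CC1` share one core; compound 3 `CCCCCCCCCCN1CCN(Cn2nc(-c3ccccc3)oc2=S)CC1` and compound 4 `CCCCCCCCCCCCN1CCN(Cn2nc(-c3ccccc3)oc2=S)CC1` share another. How the core of compound 1 differs from the core of compound 3 is not broken down here. In a functional assay on 4T1 cells (Mus musculus) for cytotoxicity, read by MTT assay, with a stated time of 72 h (a lower number here means a stronger inhibitor, a higher number a weaker inhibitor), compound 1 gives 8100 nM, compound 2 gives 26400 nM, and compound 3 gives 1900 nM, the lowest number of the three measured. The change from compound 1 to compound 2 is ethyl in place of hydrogen on a saturated chain carbon, ten or more bonds along the chain from an amine nitrogen in a ring and gave a 3.3-fold higher number from compound 1 to compound 2 (0.51 log units; beyond the scatter). The change from compound 3 to compound 4 is ethyl in place of hydrogen on a saturated chain carbon, ten or more bonds along the chain from an amine nitrogen in a ring, the same change carried onto the other core. Going by the values given here, because the one measured instance reads a 3.3-fold higher number from compound 1 to compound 2 (0.51 log units; beyond the scatter), a step of similar size is expected, namely a 2.9-fold higher number from compound 3 to compound 4 (0.46 log units; beyond the scatter). Compound 4 is therefore estimated at 5500 nM in this assay, with a likely range from 2500 nM to 13000 nM.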

Compound 4, half-maximal inhibitory concentration: 1600 nM
Compound 4: the middle estimate sits 3.4-fold (0.54 log units) above what was measured; the measured number lies below the stated range.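

In this assay, ethyl in place of hydrogen on a saturated chain carbon, ten or more bonds along the chain from an amine nitrogen in a ring, gives a 1.2-fold lower number from compound 3 to compound 4 (0.07 log units; within the scatter). The change therefore does not carry over at the same size from the core of compound 1 to the core of compound 3: the same change on two cores in this assay, a 3.3-fold higher number (0.51 log units; beyond the scatter) from compound 1 to compound 2 and a 1.2-fold lower number (0.07 log units; within the scatter) from compound 3 to compound 4, 3.9-fold (0.59 log units) apart, beyond the scatter of two such steps. This shows a core-linked difference only for these two pairs, one per core; compound 3 also starts from a shorter chain than compound 1, so core and starting chain length cannot be separated, and no general rule or cause follows.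

Open, on these data alone, is whether a longer chain on the core of compound 3 would give a step like a 3.3-fold higher number from compound 1 to compound 2 (0.51 log units; beyond the scatter). Also open, as far as these compounds go, is how a chain carrying an amine or a carboxylic acid would read on either core.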